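The compounds below may be only part of what the source reports. "The series", "measured", "known", "first", "only" and "open" are said of these compounds alone.

Compound 3 `CNc1nc(NC2(C#N)CCCCC2)nc(N2CCCC2)n1` is known in an in vitro assay on Sf21 cells for inhibition of high affinity 3',5'-cyclic-AMP phosphodiesterase 7A (Homo sapiens) (a lower number here means a stronger inhibitor, a higher number a weaker inhibitor), only as a limit: in this assay compound 3 gives > 5000 nM, a limit of the assay and not a number. Its two companions stand the same way. Compound 1 `CNc1nc(NC2(C#N)CCCCC2)nc(-n2cccn2)n1` gives in this assay > 5000 nM, which is a limit. Compound 2 `CNc1nc(NC2(C#N)CCCCC2)nc(N(C)C)n1` gives in this assay > 5000 nM, also a limit. Due to the limit of > 5000 nM in this assay, at which 3 of the 3 values shown sit, none of the steps among them can be read: the step that the two limits leave unreadable from compound 1 to compound 2, the step that the two limits leave unreadable from compound 1 to compound 3 and the step that the two limits leave unreadable from compound 2 to compound 3 all remain of unknown size and direction.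

Compound 4 `CNc1nc(C#N)nc(NC2(C#N)CCCCC2)n1` has not yet been measured in this assay. It differs from compound 3 in one place: cyano in place of pyrrolidin-1-yl on an aromatic carbon. Among the measured compounds shown here, no measured step bears on this change, since each of the three known steps only exchanges one substituent at that carbon for another and every value sits at the limit. The step that the limit leaves unreadable from compound 3 to compound 4 is therefore an expectation without a measured guide. Compound 4 is estimated to give in this assay about 8000 nM, within a range from 2000 nM to 30000 nM, and most likely to be reported again only as a limit.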

Compound 4, half-maximal inhibitory concentration: > 1000 nM
Compound 4 ended at the assay's limit; the forecaster's own chance of this, stated with the estimate: 70%; the middle value does not contradict the limit.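

Compound 4 ends at a limit, as do compound 1, compound 2 and compound 3, so no step from any of these three to compound 4 can be read: the limit of > 1000 nM in this assay, at which 1 of the 4 values shown sits.

The compounds shown leave open whether any group on that aromatic carbon gives a measurable value in this assay.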